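Working notes: phenoxymethyl tail on compound 2

The source may report more compounds than this note shows. Statements on the series, on what has been measured and on what is new or still open speak of the compounds shown alone.

Measured so far:
compound 1, `O=C(CCc1ccc(COc2ccccc2)cc1)c1ncco1`: 270 nM
compound 2, `O=C(CCc1ccc(-c2ccccc2)cc1)c1ncc(-c2cccc(-c3nnn[nH]3)n2)o1`: 100 nM

Both compounds have been run in an assay for inhibition of Fatty-acid amide hydrolase 1 (Rattus norvegicus); a lower number here means a stronger inhibitor, a higher number a weaker inhibitor. Compound 2 stands at the lower of the two numbers; compound 1 gives a higher number, and that gap is beyond the scatter. For the measured compounds named here, the two compounds differ in two places at once, so no single step between them can be read.

Compound 3, `O=C(CCc1ccc(COc2ccccc2)cc1)c1ncc(-c2cccc(-c3nnn[nH]3)n2)o1`, is not yet measured. Relative to compound 2 the change is phenoxymethyl in place of phenyl on an aromatic carbon, with the rest of the molecule unchanged. Going by the values given here, no measured pair isolates this change. The tail of compound 3 is that of compound 1, whose higher number in this assay was obtained on a differently substituted core and says nothing about the tail alone. The expected step in this assay is a 1.3-fold lower number from compound 2 to compound 3 (0.10 log units; within the scatter), not beyond the scatter. For compound 3 a value of 80 nM is expected, within 25 nM to 260 nM.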

Compound 3, half-maximal inhibitory concentration: 180 nM
Compound 3: middle estimate off by 2.3-fold (0.35 log units), on the low side; the measured number falls inside the stated range.
By their numbers in this assay, from the lowest: compounds 2, 3 and 1 (each within the scatter of the next, the first and the last beyond it).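

In this assay the position on the aromatic carbon para to a large group accepts phenoxymethyl in place of phenyl with no change beyond the scatter (a 1.8-fold higher number from compound 2 to compound 3 (0.26 log units; within the scatter)). Adding 6-(1H-tetrazol-5-yl)pyridin-2-yl in place of hydrogen on the core of compound 1 also stays within the scatter (a 1.5-fold lower number from compound 1 to compound 3 (0.18 log units; within the scatter)), so the gap between compound 1 and compound 2 resolves into two single changes, neither of which is beyond the scatter alone. Nothing available gives a reason for either step.

Still open, going by these compounds, is whether a group of another kind at the tail position, such as an amine, a carboxylic acid or a longer alkyl chain, would move the number beyond the scatter. Also open, on these data alone, is whether the pyridinyl-tetrazole step reads the same with a phenyl tail.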